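A few compounds are considered here, and "the series" means these few. Any claim that something is new, unique, unknown or untested is made for them only; others in the source may bear on it.

Measured so far in an ADME assay on HepG2 2.2.15 cells (Homo sapiens) for cytotoxicity; on this read-out lower numbers stand for higher toxicity in this test and higher numbers for lower toxicity in this test:
compound 1, `CC(C)(C)OC(=O)Nc1ncc(C(Oc2cccc(C#N)c2)c2ccc(Cl)cc2)s1`, gives > 50000 nM, which is a limit of the assay.
compound 2, `Cc1cc(Br)cc(OC(c2ccc(Cl)cc2)c2cnc(NC(=O)OC(C)(C)C)s2)c1`, gives > 50000 nM, also a limit.
compound 3, `COC(=O)CCCCNc1ncc(C(Oc2ccc3cc(Br)ccc3c2)c2ccc(Cl)cc2)s1`, is reported as "not toxic" (no number reported), without a number.

Compound 3 therefore has no number in this assay; the two other values in the series sit at the limit of > 50000 nM in this assay, at which 2 of the 3 values shown sit, and compound 3 is described only in words, on the same side of the read-out. Among the measured compounds shown here, the one step between measured compounds, a step that the two limits leave unreadable from compound 1 to compound 2, cannot be read, since both of its ends are limits.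

Compound 4, `O=C(Nc1ncc(C(Oc2ccc3cc(Br)ccc3c2)c2ccc(Cl)cc2)s1)c1ccc(Cl)nc1`, has not yet been measured. It differs from compound 3 by (6-chloropyridin-3-yl)carbonyl in place of 4-(methoxycarbonyl)butyl on a nitrogen on an aromatic ring. For the measured compounds named here, no measured step in this assay bears on this change: the only step joins compound 1 and compound 2, and its size is not readable. Going by the values given here, there is thus no basis for expecting a shift of a particular size or direction in this assay; the series so far offers only limits and a verbal report of no toxicity.

Compound 4 is accordingly expected to give about 50000 nM in this assay, within a range of 20000 nM to 100000 nM, with a limit rather than a number the more likely report.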

Compound 4, half-maximal cytotoxic concentration: "not toxic" (no number reported)
Nothing numeric was reported for compound 4; no gap can be computed for the estimate.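

In this assay, compound 3 and compound 4 are both reported only as "not toxic", without a number, so no step can be read between them. The compounds shown leave open whether (6-chloropyridin-3-yl)carbonyl in place of 4-(methoxycarbonyl)butyl changes the read-out at all, the only figures given being limits: the limit of > 50000 nM in this assay, at which 2 of the 4 values shown sit.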